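The compounds below may be only part of what the source reports. "The series", "measured", "known", "first", "only" and "open" are said of these compounds alone.

In a functional assay on SW-620 cells (Homo sapiens) for inhibition, read by MTT assay, with a stated time of 72 h (on this read-out lower numbers stand for stronger inhibition of growth and higher numbers for weaker inhibition of growth), compound 3 `CCn1cc(-c2nc3c(N4CCN(Cc5cc(C)on5)CC4)c(Cl)cnc3[nH]2)cn1` gives 2180 nM, compound 1 `Cc1cc(CN2CCN(c3c(Cl)cnc4[nH]c(-c5cnn(C)c5)nc34)CC2)no1` gives 1800 nM and compound 2 `Cc1cc(CN2CCN(c3c(Cl)cnc4[nH]c(-c5ccn(C)n5)nc34)CC2)no1` gives 2600 nM. All three lie within the scatter of one another, so compound 3 holds no distinct place among them. Compound 4 `Cc1cc(CN2CCN(c3c(Cl)cnc4[nH]c(-c5cc(C)on5)nc34)CC2)no1` carries 5-methyl-1,2-oxazol-3-yl in place of 1-ethyl-1H-pyrazol-4-yl on an aromatic carbon, that is, 5-methyl-1,2-oxazol-3-yl in place of 1-ethyl-1H-pyrazol-4-yl on an aromatic carbon. The measured changes to this group are small: a 1.4-fold higher number from compound 1 to compound 2 (0.16 log units; within the scatter), a 1.2-fold higher number from compound 1 to compound 3 (0.08 log units; within the scatter) and a 1.2-fold lower number from compound 2 to compound 3 (0.08 log units; within the scatter), all within the scatter. None of them tests the incoming group on that carbon, so the range stays wide. No step beyond the scatter is expected in this assay, and no direction can be called. The expected step is a 1.0-fold higher number from compound 3 to compound 4 (0.00 log units; within the scatter). Compound 4 is estimated at 2200 nM, with an expected range of 1000 nM to 5000 nM.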

Compound 4, concentration for 50% growth inhibition: 1150 nM
Compound 4: middle estimate off by 1.9-fold (0.28 log units), on the high side; measured number inside the range.
By their numbers in this assay, from the lowest: compounds 4, 1, 3 and 2 (each within the scatter of the next, the first and the last beyond it).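

At this aromatic carbon, 5-methyl-1,2-oxazol-3-yl is the first group shown that is not a pyrazolyl, and in this assay it gives the only step beyond the scatter, and a modest one, against 1-methyl-1H-pyrazol-3-yl (a 2.3-fold lower number from compound 2 to compound 4 (0.35 log units; beyond the scatter)). Against the other two pyrazolyl groups the steps stay within the scatter (a 1.9-fold lower number from compound 3 to compound 4 (0.28 log units; within the scatter); a 1.6-fold lower number from compound 1 to compound 4 (0.19 log units; within the scatter)). The swap is therefore tolerated, with no clear gain across the set, and nothing available bears on a cause.

From the compounds shown here alone, whether the methyl on the incoming ring matters remains open. So does the effect of a basic amine or a carboxylic acid on this carbon.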